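Methoxyphenyl positional swap on a triazole: series notes

A few compounds are considered here, and "the series" means these few. Any claim that something is new, unique, unknown or untested is made for them only; others in the source may bear on it.

Compound 1 `COc1ccc(-n2nncc2CN2C(=O)C3(C(C#N)=C(N)Oc4c3c3nc5ccccc5nc3c3ccccc43)c3ccccc32)cc1` and compound 2 `COc1ccccc1-n1nncc1CN1C(=O)C2(C(C#N)=C(N)Oc3c2c2nc4ccccc4nc2c2ccccc32)c2ccccc21` share one core and differ only in the group on the triazole nitrogen. In an ADME assay on HUVEC cells (Homo sapiens) for antiproliferative activity, read by MTT assay, with a stated time of 48 h (a higher number here means a weaker inhibitor, a lower number a stronger inhibitor), compound 1 gives > 50000 nM, which is a limit of the assay and not a number. In this assay compound 2 gives > 50000 nM, again a limit. The change between the two is 2-methoxyphenyl in place of 4-methoxyphenyl on an aromatic nitrogen. The step that the two limits leave unreadable from compound 1 to compound 2 cannot be sized, because the limit of > 50000 nM in this assay, at which 3 of the 3 values shown sit, shows both of these values sitting at the limit.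

Compound 3 `COc1ccc(-n2nncc2CN2C(=O)C3(C(C#N)=C(N)Oc4c(N)cc5nc6ccccc6nc5c43)c3ccccc32)cc1` carries a different core; the difference between the cores of compound 1 and compound 3 is not broken down here. In this assay compound 3 gives > 50000 nM, a limit as well.

Compound 4 `COc1ccccc1-n1nncc1CN1C(=O)C2(C(C#N)=C(N)Oc3c(N)cc4nc5ccccc5nc4c32)c2ccccc21` has not been measured. It stands to compound 3 exactly as compound 2 stands to compound 1: the change is 2-methoxyphenyl in place of 4-methoxyphenyl on an aromatic nitrogen, the same change at the same place. Since the measured instance of this change left both ends at the limit, no direction is readable, and with compound 3 already at > 50000 nM in this assay, the expected step that the limit leaves unreadable from compound 3 to compound 4 is taken as essentially flat. Compound 4 is therefore expected to be reported in this assay as a limit again, with an estimate of 80000 nM and a plausible range from 40000 nM to 200000 nM.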

Compound 4, half-maximal inhibitory concentration: > 50000 nM
Compound 4: only a limit was reported; the forecaster's own chance of this, stated with the estimate: 90%; the middle value does not contradict the limit.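

In this assay compound 4 gives > 50000 nM as a limit of the assay and not a number. No step can be read from compound 3 to compound 4, because the values of both sit at the same limit: the limit of > 50000 nM in this assay, at which 4 of the 4 values shown sit.

The compounds shown leave open whether 2-methoxyphenyl and 4-methoxyphenyl on the triazole differ at all in this assay for any compound that reads inside the limit.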